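The compounds below may be only part of what the source reports. "The series", "measured", "known", "first", "only" and "open" are said of these compounds alone.

Working notes on the series. a functional assay on TK-10 cells (Homo sapiens) for cytotoxicity, read by sulforhodamine B assay, with a stated time of 48 h (on this read-out higher numbers stand for lower toxicity in this test and lower numbers for higher toxicity in this test), has so far been run on two compounds of the shared core. Compound 1 `ClCc1ccc(Cn2cnc3c(Cl)ncnc32)cc1` gives 22900 nM in this assay. Compound 2 `ClCc1ccc(Cn2cnc3nc(Cl)nc(Cl)c32)cc1` gives 720 nM in this assay, the lowest of the two numbers; its nearest neighbour is compound 1, whose number is higher by a gap beyond the scatter. The two compounds differ in more than one place, so only their two values can be set side by side, not a single step.

The next compound, compound 3 `ClCc1ccc(Cn2cnc3ncnc(Cl)c32)cc1`, is taken from compound 2 by one change: hydrogen in place of chloro on an aromatic carbon. For the measured compounds named here, no measured pair shows this change, so the size of the step is open. Going by the values given here, with only two numbers in hand, the expectation for compound 3 in this assay is a higher number than compound 2, set roughly midway between the two measured values, and the step from compound 2 is estimated as a 6.9-fold higher number from compound 2 to compound 3 (0.84 log units; beyond the scatter). Compound 3 is expected to give about 5000 nM in this assay, within a range from 1500 nM to 20000 nM.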

Compound 3, concentration lethal to 50% of the cells: 5750 nM
Compound 3: middle estimate off by 1.2-fold (0.06 log units), on the low side, within the range that was stated.
By their numbers in this assay, from the lowest: compound 2; then compound 3; then compound 1.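

In this assay, the series now has its first step in a single place, an 8.0-fold higher number from compound 2 to compound 3 (0.90 log units; beyond the scatter), and it shows that the read-out responds to the group on this aromatic carbon between two ring nitrogen atoms. With the rest of the structure unchanged, including the chloro group meta to this carbon, chloro at this position goes with the lower number, and so with higher toxicity in this test, while hydrogen goes with the higher number. Nothing in the data at hand accounts for the size of this step.

As far as these compounds go, at this position only chloro and hydrogen can be compared, so it remains open where an amine, a methoxy group, a carboxylic acid or a longer alkyl chain would fall in this read-out. The step also rests on one pair of compounds, which leaves open whether the same exchange would give a step of similar size with a different group in place of the remaining chloro group.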